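This account rests on a few compounds, and the source may have more. Where it says the series, first, only, none or still open, it means among the compounds named here.

Within the data shown here, in a functional assay on Jurkat cells (Homo sapiens) (on this read-out higher numbers stand for weaker inhibition and lower numbers for stronger inhibition), compound 3 `C[C@H](NC(=O)C(=O)NCC1(c2ccccc2)CC1)C(=O)N[C@@H](CC(=O)O)C(=O)COc1c(F)c(F)cc(F)c1F` gives 27 nM, the highest number of the three measured so far. Against it, compound 1 `C[C@H](NC(=O)C(=O)NCc1ccc(Cl)cc1)C(=O)N[C@@H](CC(=O)O)C(=O)COc1c(F)c(F)cc(F)c1F` gives 8.4 nM and compound 2 `C[C@H](NC(=O)C(=O)NCCC1CCCC1)C(=O)N[C@@H](CC(=O)O)C(=O)COc1c(F)c(F)cc(F)c1F` gives 11 nM, two values within the scatter of each other. The next structure, compound 4 `C[C@H](NC(=O)C(=O)NCc1ccc(F)cc1)C(=O)N[C@@H](CC(=O)O)C(=O)COc1c(F)c(F)cc(F)c1F`, brings this change: 4-fluorophenyl in place of 1-phenylcyclopropyl on a saturated chain carbon bound to an amide-type nitrogen. In words, 4-fluorophenyl takes the place of 1-phenylcyclopropyl on a saturated chain carbon bound to an amide-type nitrogen. The closest guide is the modest 3.2-fold higher number from compound 1 to compound 3 (0.51 log units; beyond the scatter), where 1-phenylcyclopropyl replaced 4-chlorophenyl, and the modest 2.5-fold higher number from compound 2 to compound 3 (0.39 log units; beyond the scatter) also bears on it. Undoing such a swap with a similar halogen-bearing phenyl group suggests a modest move towards stronger inhibition. The expected size is a 2.7-fold lower number from compound 3 to compound 4 (0.43 log units; beyond the scatter). For compound 4 the estimate is 10 nM, with a range from 4.5 nM to 22 nM.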

Compound 4, half-maximal inhibitory concentration: 197 nM
The estimate for compound 4 lay 20-fold (1.29 log units) below the measured number; measured number above the stated range.
By their numbers in this assay, from the lowest: compounds 1 and 2 (each within the scatter of the next); then compound 3; then compound 4.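

In this assay, fluoro in place of chloro on an aromatic carbon gives a 23-fold higher number from compound 1 to compound 4 (1.37 log units; beyond the scatter) and so shows that this single halogen matters more here than the earlier swaps of the whole group did. 4-Fluorophenyl also does worse than 1-phenylcyclopropyl with a 7.3-fold higher number from compound 3 to compound 4 (0.86 log units; beyond the scatter) and worse than cyclopentylmethyl with an 18-fold higher number from compound 2 to compound 4 (1.25 log units; beyond the scatter) so a halogen-bearing phenyl does not by itself secure strong inhibition at this position. Nothing measured here accounts for this loss. As far as these compounds go, whether unsubstituted phenyl or 4-bromophenyl would lie closer to compound 1 or to compound 4 remains open.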